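This account rests on a few compounds, and the source may have more. Where it says the series, first, only, none or still open, it means among the compounds named here.

Of the compounds shown here, three built on one shared core have been tested in a functional assay on the whole organism (strain Wistar) for inhibition, with Rattus norvegicus as the target, with stated times of 30 min and 2 h, at a dose of 20 mg/kg by the oral route; on this read-out higher numbers stand for more inhibition at the one dose given (going by the name of the read-out) and lower numbers for less inhibition. Compound 1 `O=C(CCc1nnc(-c2ccc(Cl)cc2)o1)c1ccccc1` gives 42%. Compound 2 `Cc1ccc(C(=O)CCc2nnc(-c3ccccc3)o2)cc1` gives 33.3%, and compound 3 `Cc1ccc(C(=O)CCc2nnc(-c3ccccc3)o2)c(C)c1` gives 36%. The numbers for compound 1 and compound 2 both lie within the usual scatter of the number for compound 3, so the three compounds cannot be separated on this read-out. For the measured compounds named here, the one step between compounds that differ in a single place, a number 2.7 percentage points higher from compound 2 to compound 3 (within the scatter), also stays within the scatter.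

Compound 4 `Cc1ccc(C(=O)CCc2nnc(-c3ccc(Cl)cc3)o2)c(C)c1` is the next compound, and it differs from compound 3 by chloro in place of hydrogen on an aromatic carbon. Going by the values given here, no measured step isolates this change: compound 1 carries the chloro group, but it differs from compound 3 in more than one place, and its value and that of compound 3 lie within the scatter of each other. Among the compounds with values here, the only single-place step measured, a number 2.7 percentage points higher from compound 2 to compound 3 (within the scatter), concerns a methyl group rather than a chloro group and was itself within the scatter. With nothing pointing to a large effect in this assay, the step from compound 3 to compound 4 is expected to stay within the scatter. The expected step is a number 4 percentage points higher from compound 3 to compound 4 (within the scatter). Compound 4 is therefore estimated at 40%, within a range from 25% to 55%.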

Compound 4, a percentage reported as inhibition, in the whole organism at one dose (the size of the read-out at that dose, not a potency): 53.3%
The estimate for compound 4 lay 13.3 percentage points below the measured number, within the range that was stated.
By their numbers in this assay, from the lowest: compounds 2, 3 and 1 (each within the scatter of the next); then compound 4.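

For the compounds shown here, changing phenyl to 4-chlorophenyl is the first single change here to pass the usual scatter in this assay: the chloro group, on an aromatic carbon of the ring and para to a large group, gives a number 17.3 percentage points higher from compound 3 to compound 4 (beyond the scatter), whereas the methyl change gave only a number 2.7 percentage points higher from compound 2 to compound 3 (within the scatter). Going by these compounds alone, with the 4-chlorophenyl group held constant, the other end of the molecule also proves to matter, as 2,4-dimethylphenyl in place of phenyl on the carbonyl carbon gives a number 11.3 percentage points higher from compound 1 to compound 4 (beyond the scatter), a difference that the earlier compounds could not reveal. No measurement here explains why either change raises the number.

The compounds shown leave open whether this rise is specific to chloro or would also appear with fluoro, bromo, methoxy or trifluoromethyl in the same place on the ring. As far as these compounds go, it also remains open how the number would respond to a longer chain between the carbonyl and the shared core, or to an amine or a carboxylic acid on either aromatic ring.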